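The source may hold more compounds than are shown below. What is called first, only, known or untested is meant among the compounds shown, and "the series" means these compounds.

Measured in a functional assay on the whole organism (strain Kunming) with Mus musculus as the target, with a stated time of 0.5 h; on this read-out higher numbers stand for an effect only at larger amounts of compound and lower numbers for an effect already at smaller amounts:
Compound 1 `COc1cc(OC)c(OC)cc1/C=C/COC(=O)/C=C/c1c(OC)ccc(OC)c1OC`: 53.5 mg/kg
Compound 2 `COc1cc(OC)c(OC)cc1/C=C/COC(=O)/C=C/c1ccc(Br)cc1`: 61.8 mg/kg
Compound 3 `COc1cc(OC)c(OC)cc1/C=C/COC(=O)/C=C/c1cc(OC)c(OC)c(OC)c1`: 33.2 mg/kg

In this small set, compound 2 gives 61.8 mg/kg in this assay. That value lies within the usual scatter of both compound 1 and compound 3, so the three numbers cannot be ranked with any confidence. Going by the values given here, no two of the measured compounds differ in one place alone, which means that the data offer no direct step to serve as a guide.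

The account now turns to compound 4 `COc1cc(OC)c(OC)cc1/C=C/COC(=O)/C=C/c1ccc(F)cc1`, which has not yet been measured. It differs from compound 2 in a single place, with fluoro in place of bromo on an aromatic carbon, para to a large group: fluoro in place of bromo on an aromatic carbon. Compound 1 at 53.5 mg/kg and compound 3 at 33.2 mg/kg carry other substituents, yet both remain within the scatter of compound 2, so a change of one halogen is expected to produce no shift beyond the scatter, in either direction. The expected change is a 1.2-fold lower number from compound 2 to compound 4 (0.07 log units; within the scatter), an estimated step that stays within the scatter. The estimate for compound 4 is 52 mg/kg, with an expected range from 27 mg/kg to 100 mg/kg.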

Compound 4, dose for half-maximal effect: 34.6 mg/kg
The estimate for compound 4 lay 1.5-fold (0.18 log units) above the measured number, and the stated range covers the measured number.
By their numbers in this assay, from the lowest: compounds 3, 4, 1 and 2 (each within the scatter of the next).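

Going by these compounds alone, the exchange of bromo for fluoro gives the first comparison in this set in which only one place differs, and in this assay it reads as a 1.8-fold lower number from compound 2 to compound 4 (0.25 log units; within the scatter). For this position, on an aromatic carbon para to a large group, the change from 4-bromophenyl to 4-fluorophenyl therefore produces no shift that can be told apart from the scatter, so the two halogens cannot be separated by this read-out. The available data offer no independent measurement that bears on this result.

The compounds shown leave open whether a group other than a halogen at this same place, such as an amine, a carboxylic acid or a nitrile, or simply a hydrogen, would give a step beyond the scatter. They also leave open whether fluoro in place of bromo would read the same way in a compound with a different core, and how the methoxy groups carried by compound 1 and compound 3 contribute, since neither differs from compound 2 or compound 4 in one place alone.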